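This account rests on a few compounds, and the source may have more. Where it says the series, first, only, none or still open, it means among the compounds named here.

Measured so far in a functional assay on DU-145 cells (Homo sapiens) for inhibition, read by trypan blue exclusion, with a stated time of 96 h; on this read-out higher numbers stand for weaker inhibition of growth and lower numbers for stronger inhibition of growth:
- compound 1 `COc1cc(/C=C(\C(=O)c2ccc(Cl)cc2)S(=O)(=O)Cc2ccccc2Cl)cc(OC)c1`: > 100000 nM (a limit of the assay, not a number)
- compound 2 `O=C(/C(=C\c1ccccc1OCc1ccccc1)SCc1ccc(Cl)c(Cl)c1)c1ccc(Cl)cc1`: 10000 nM

Not yet measured: compound 3 `COc1ccc(/C=C(\C(=O)c2ccc(Cl)cc2)S(=O)(=O)Cc2ccccc2Cl)cc1`.

Compound 1 stands at the limit of > 100000 nM in this assay, at which 1 of the 2 values shown sits, so its position is known only as a limit. Among the compounds with values here, no step between measured compounds is available to guide the next comparison. Compound 3 keeps the core of compound 1, and the change is 4-methoxyphenyl in place of 3,5-dimethoxyphenyl on a double-bonded chain carbon bound to a double-bonded chain carbon.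

In this assay, the expectation is a modest shift towards stronger inhibition of growth, although the reading may again stop at the limit. Within the data shown here, the only numerical reference is compound 2 at 10000 nM, so the expectation is loose. The expected size of the move is an at least 2.5-fold lower number from compound 1 to compound 3 (0.39 log units; beyond the scatter). For compound 3, the estimate is 40000 nM, with an expected range of 8000 nM to 100000 nM.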

Compound 3, concentration for 50% growth inhibition: 50000 nM
For compound 3 the middle estimate is 1.3-fold (0.10 log units) below the measured one; measured number inside the range.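

In this assay, 4-methoxyphenyl in place of 3,5-dimethoxyphenyl on a double-bonded chain carbon bound to a double-bonded chain carbon gives an at least 2.0-fold lower number from compound 1 to compound 3 (0.30 log units; that floor lies within the scatter). Compound 3, at 50000 nM, therefore provides a measured number for the core of compound 1, so this position can be read on the scale of the assay. Even so, the floor of the step does not show a change beyond the scatter. The step remains only a floor because compound 1 is held at a limit of the assay, not a number: the limit of > 100000 nM in this assay, at which 1 of the 3 values shown sits.

On these data alone, how far the true step lies beyond that floor remains open, and compound 2 differs from both other compounds in more than one place, so it does not settle the matter. A plain phenyl or a 4-aminophenyl at this position would show whether the methoxy group itself matters.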